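This account rests on a few compounds, and the source may have more. Where it says the series, first, only, none or still open, it means among the compounds named here.

Working notes on the series. Compound 1 `COc1ccc(CNc2ncc(C(=O)O)c3nc(-c4ccco4)nn23)cc1OC` gives in a functional assay on CHO cells for antagonist activity at adenosine receptor A2b (Homo sapiens) (a higher number here means a weaker inhibitor, a lower number a stronger inhibitor), only a limit of the assay, > 30000 nM. Compound 2 `CNC(=O)c1cnc(NC(=O)NC2CCCCC2)n2nc(-c3ccco3)nc12` likewise reaches only a limit, > 30000 nM. Among the measured compounds shown here, compound 3 `CCOC(=O)c1cnc(NCc2ccc(F)cc2)n2nc(-c3ccco3)nc12` gives 1970 nM in this assay, the sole actual number among the three values shown, the other two sitting at the limit of > 30000 nM in this assay, at which 2 of the 3 values shown sit. Compound 4 `CCOC(=O)c1cnc(NC2CCCCC2)n2nc(-c3ccco3)nc12` differs from compound 3 by cyclohexyl in place of 4-fluorobenzyl on a nitrogen on an aromatic ring, which is cyclohexyl in place of 4-fluorobenzyl on a nitrogen on an aromatic ring. For the measured compounds named here, no measured pair isolates this change, so its size is open. A modest loss is expected, a 2.5-fold higher number from compound 3 to compound 4 (0.40 log units; beyond the scatter), with a real chance of falling to a limit. Compound 4 is estimated at 5000 nM, within 1500 nM to 30000 nM.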

Compound 4, inhibition constant: > 10000 nM
Compound 4 was reported as a limit; the forecaster's own chance of this, stated with the estimate: 30%; middle value at least 2.0-fold (0.30 log units) from the limit.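

In this assay, among the compounds shown here, cyclohexyl in place of 4-fluorobenzyl on a nitrogen on an aromatic ring gives the first readable step, an at least 5.0-fold higher number from compound 3 to compound 4 (0.70 log units; beyond the scatter), so activity at this position depends on the group it carries. The true size of the step stays open, since compound 4 gives only a limit of the assay: the limit of > 10000 nM in this assay, at which 1 of the 4 values shown sits.

The compounds shown do not separate the contributions of the fluorine, the aromatic ring and the carbon link of 4-fluorobenzyl. Unsubstituted benzyl or cyclohexylmethyl on the same nitrogen would begin to separate them.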